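This account rests on a few compounds, and the source may have more. Where it says the series, first, only, none or still open, it means among the compounds named here.

Measured compounds:
compound 1 `[N-]=[N+]=N[C@]1(CO)O[C@@H](n2ccc(N)nc2=O)[C@H](O)[C@@H]1O` — > 80000 nM
compound 2 `[N-]=[N+]=N[C@]1(CO)O[C@@H](n2ccc(N)nc2=O)[C@@H](O)[C@@H]1O` — > 100000 nM

In an ADME assay on HeLa cells (Homo sapiens) for cytotoxicity, read by luminescence and CellTiter-Glo (on this read-out lower numbers stand for higher toxicity in this test and higher numbers for lower toxicity in this test), compound 1 reaches only a limit, > 80000 nM. In this assay compound 2 likewise reaches only a limit, > 100000 nM. The step that the two limits leave unreadable from compound 1 to compound 2 is therefore unreadable, as the two values sit at the limit of > 80000 nM in this assay, at which 1 of the 2 values shown sits, and (the limit of > 100000 nM in this assay, at which 1 of the 2 values shown sits); the pair differs by a single stereocentre, (the fact that one of compounds 1 and 2 is drawn with a defined configuration and the other without, at the place where they differ), and the numbers show nothing beyond the two limits. Going by the values given here, compound 2 thus stands at a limit of this assay with no numeric value, and the one other measured value is a limit as well.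

Compound 3 `Nc1ccn([C@@H]2O[C@@](CO)(CCl)[C@@H](O)[C@@H]2O)c(=O)n1` differs from compound 2 by chloromethyl in place of azido on a saturated ring carbon

Among the compounds with values here, no measured step bears on this change: the only step in hand, a step that the two limits leave unreadable from compound 1 to compound 2, is unreadable and concerns a stereocentre, not the azido group. On the evidence of the two limits, compound 3 is expected to show no step beyond the scatter, a number no higher from compound 2 to compound 3 (the limit leaves the size open), and most likely to return a limit again. For compound 3 the estimate in this assay is 100000 nM, within 30000 nM to 300000 nM.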

Compound 3, half-maximal cytotoxic concentration: > 100000 nM
Compound 3 ended at the assay's limit (the forecaster's own chance of this, stated with the estimate: 70%); the middle value lies on the limit itself.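

In this assay compound 3 gives > 100000 nM, which is a limit. Compound 2 also sits at a limit, so no step can be read between compound 2 and compound 3. The compounds shown leave open what numeric cytotoxic concentration any of them would reach, and whether chloromethyl in place of azido changes it.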